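The source may hold more compounds than are shown below. What is called first, only, known or untested is meant among the compounds shown, and "the series" means these compounds.

Of the compounds shown here, two have so far been measured in an in vitro functional assay on cells for agonist activity at Bombesin receptor subtype-3 (Mus musculus), read by luminescence and calcium flux; a higher number here means that more compound is needed for the effect, a lower number that less compound is needed. Compound 1 `CCCCc1cnc(Cc2ccc(-c3ccccc3C(=O)O)cc2)[nH]1` returns only a limit of this assay, > 10000 nM; that is the limit described by the limit of > 10000 nM in this assay, at which 1 of the 2 values shown sits. Compound 2 `O=C(O)c1ccccc1-c1ccc(CCc2ncc(Cc3ccc(Cl)cc3)[nH]2)cc1` gives 102 nM in this assay. Among the values shown, compound 2 therefore stands as the only measured number, while the other value is a limit and cannot be compared with it beyond saying that compound 2 clearly lies inside the range of this assay.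

Compound 3 `N#Cc1ccccc1Cc1cnc(CCc2ccc(-c3ccccc3C(=O)O)cc2)[nH]1` is the next compound to be tested. It differs from compound 2 in one place: 2-cyanophenyl in place of 4-chlorophenyl on a saturated chain carbon bound to an aromatic carbon.

Going by the values given here, no step between two measured compounds is available for this kind of change, so there is no measured guide to its size. The expectation is a small to moderate step from compound 2 to compound 3, a 2.5-fold higher number from compound 2 to compound 3 (0.39 log units; beyond the scatter), toward more compound being needed, close to the edge of the usual scatter. For compound 3 the estimate in this assay is 250 nM, expected to fall between 60 nM and 1200 nM.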

Compound 3, half-maximal effective concentration: 642 nM
For compound 3 the middle estimate is 2.6-fold (0.41 log units) below the measured one, and the stated range covers the measured number.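

Going by these compounds alone, this is the first measured step at this place, and it shows that the group on the saturated chain carbon bound to an aromatic carbon is not a free choice: in this assay, 2-cyanophenyl in place of 4-chlorophenyl gives a 6.3-fold higher number from compound 2 to compound 3 (0.80 log units; beyond the scatter), a step beyond the usual scatter. Compound 3 still returns a real number, 642 nM, so this change leaves it inside the range of the assay, with more compound needed for the effect. The two groups differ both in the substituent, nitrile against chlorine, and in the number of its place on the ring, and nothing measured here accounts for the size of the step.

Within the data shown here, with both parts changing at once, the single step cannot say which of them carries the difference, and 2-chlorophenyl or 4-cyanophenyl at this place would be needed to pull them apart. Also open, from the compounds shown here alone, is how a plain phenyl, with neither chlorine nor nitrile, would read in this assay as a baseline for both groups.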